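The source may hold more compounds than are shown below. What is called first, only, known or untested is meant among the compounds shown, and "the series" means these compounds.

Measured so far in an assay on brain (strain C57BL6) for displacement of a labelled ligand from AP2-associated protein kinase 1 (Mus musculus), read by scintillation counting, with a stated time of 1 h; on this read-out higher numbers stand for weaker inhibition and lower numbers for stronger inhibition:
- compound 1 `Cc1cc(-c2ccnc(C(F)F)c2)ncc1OC[C@@](C)(N)CC(C)C`: 0.3 nM
- compound 2 `CC(=O)Nc1cc(-c2ccc(OC[C@@H](N)CC(C)C)c(F)c2)ccn1`: 0.52 nM
- compound 3 `CC(=O)Nc1cc(-c2cc(F)c(OC[C@@H](N)CC(C)C)c(F)c2)ccn1`: 27 nM

Compound 1 gives the lowest of the three numbers in this assay. Compound 2 sits within the scatter of compound 1, so the two cannot be ordered. Among the measured compounds shown here, compound 3 stands well apart; the one step that differs in a single place, a 52-fold higher number from compound 2 to compound 3 (1.72 log units; beyond the scatter), is a large move toward weaker inhibition.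

Compound 4 `COC(=O)Nc1cc(-c2cc(C)c(OC[C@@](C)(N)CC(C)C)cn2)ccn1` differs from compound 1 by one exchange: (methoxycarbonyl)amino in place of difluoromethyl on an aromatic carbon. For the measured compounds named here, no measured step covers this exchange. Going by the values given here, the only step on record concerns a fluoro for a hydrogen and says nothing about swapping a difluoromethyl for a (methoxycarbonyl)amino. Compounds 2 and 3 show that a hydrogen-bond-donating group on the core is compatible with a low number, as the value of compound 2 shows, but no pairwise comparison isolates that group. The expectation is therefore a step of a 1.7-fold higher number from compound 1 to compound 4 (0.22 log units; within the scatter), no larger than the scatter and in no firm direction. Compound 4 is estimated at 0.5 nM, within 0.15 nM to 2 nM.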

Compound 4, inhibition constant: 1.4 nM
Beside the measured number, compound 4's estimate is 2.8-fold (0.45 log units) below it, within the range that was stated.
By their numbers in this assay, from the lowest: compounds 1 and 2 (each within the scatter of the next); then compound 4; then compound 3.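

In this assay, among the compounds shown here, the exchange of difluoromethyl for (methoxycarbonyl)amino, on an aromatic carbon next to the ring nitrogen, gives a 4.7-fold higher number from compound 1 to compound 4 (0.67 log units; beyond the scatter) and is the first reading of any change at this position. The step is modest, so this position tolerates the larger group with its hydrogen-bond donor and acceptors at a cost that lies beyond the scatter, and compound 4 stays at 1.4 nM in the low range of the series. No measurement on hand accounts for the size of this step.

Among compounds that differ only at this position, just difluoromethyl and (methoxycarbonyl)amino appear, so a plain amine, a methoxy group or a nitrile remains unplaced against them. For the compounds shown here, it also stays open whether the step follows the hydrogen-bond donor or the added heavy atoms, as no pair separates the two.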